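Replacing the trifluoromethoxyphenyl amide with a methylsulfonylphenyl amide

This account rests on a few compounds, and the source may have more. Where it says the series, first, only, none or still open, it means among the compounds named here.

Measured compounds:
Compound 1 `NC(=O)c1ccccc1C(=O)N1CCC(N(C2CC2)S(=O)(=O)c2cccc(C(F)(F)F)c2)CC1` — 11%
Compound 2 `NC(=O)c1cccc(C(=O)N2CCC(N(C3CC3)S(=O)(=O)c3cccc(C(F)(F)F)c3)CC2)c1` — "not determined" (no result reported)
Compound 3 `O=C(c1ccc(OC(F)(F)F)cc1)N1CCC(N(C2CC2)S(=O)(=O)c2cccc(C(F)(F)F)c2)CC1` — 73%

In an assay on cells for inhibition of Voltage-dependent L-type calcium channel subunit alpha-1C (Homo sapiens), read by FLIPR and calcium flux, tested at 1 uM (on this read-out higher numbers stand for a stronger effect at the one concentration tested and lower numbers for a weaker effect), compound 3 gives 73% and stands highest of the two numbers available; its nearest neighbour is compound 1, which gives 11%. Compound 2 carries a 3-carbamoylphenyl group on the carbonyl carbon but has no reported result.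

Compound 4 `CS(=O)(=O)c1ccccc1C(=O)N1CCC(N(C2CC2)S(=O)(=O)c2cccc(C(F)(F)F)c2)CC1` differs from compound 3 in one place: 2-(methylsulfonyl)phenyl in place of 4-(trifluoromethoxy)phenyl on a carbonyl carbon. Among the compounds with values here, the one measured step that bears on this change is a number 62 percentage points higher from compound 1 to compound 3 (beyond the scatter), which shows how much the read-out in this assay moved when the 2-carbamoylphenyl group of compound 1 was exchanged for the 4-(trifluoromethoxy)phenyl group of compound 3. Compound 4 reverses that direction, putting a 2-(methylsulfonyl)phenyl group, again with two hydrogen-bond acceptors and no donor, on the same carbonyl carbon. A step downward beyond the scatter is therefore expected, of about a number 53 percentage points lower from compound 3 to compound 4 (beyond the scatter), because compound 1 gives only 11%. Compound 4 is estimated at 20%, within a range from 0% to 45%.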

Compound 4, a percentage reported as inhibition, at one concentration (the size of the read-out at that concentration, not a potency): 19%
Beside the measured number, compound 4's estimate is 1 percentage points above it, and the stated range covers the measured number.
By their numbers in this assay, from the lowest: compounds 1 and 4 (each within the scatter of the next); then compound 3.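

In this assay, the exchange on the carbonyl carbon gives a number 54 percentage points lower from compound 3 to compound 4 (beyond the scatter), so this position responds strongly to a change that removes the 4-(trifluoromethoxy)phenyl group even when the group that enters, 2-(methylsulfonyl)phenyl, has 0 hydrogen-bond donors. Methylsulfonyl in place of carbamoyl on the aromatic carbon gives a number 8 percentage points higher from compound 1 to compound 4 (within the scatter), so the low read-out seen with compound 1 does not require the carbamoyl group and its amide hydrogens. No measurement shown here explains either step.

On these data alone, whether the read-out follows the substituent itself or its place on the phenyl ring stays open, since compound 3 and compound 4 differ in both. As far as these compounds go, how a phenyl ring carrying a carboxylic acid or an amine would read in this assay also remains open.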